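A Fluorinated Chain Replaces Cyclopentyl: Plasma Binding Outlook

This account rests on a few compounds, and the source may have more. Where it says the series, first, only, none or still open, it means among the compounds named here.

Of the compounds shown here, two have so far been tested in an ADME assay on a cell-free system (plasma, Mus musculus) for protein binding. Compound 1 `Cc1ccc(C(=O)Nc2cn3ncnc3c(CN3CCN(C(=O)C4CCCC4)[C@@H](C)C3)c2C)cn1` gives 78.8% in this assay. Compound 2 `Cc1ccc(C(=O)Nc2cc(F)cc(CN3CCN(C(=O)C4CCCC4)[C@@H](C)C3)c2C)cn1` has a different core from compound 1. In this assay compound 2 gives 95.7%. Of the two measured values, compound 1 has the larger unbound fraction, and its gap to compound 2 lies beyond the usual scatter of repeated measurements of this kind.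

Compound 3 `Cc1ccc(C(=O)Nc2cn3ncnc3c(CN3CCN(C(=O)CC(C(F)(F)F)C(F)(F)F)[C@@H](C)C3)c2C)cn1` has not yet been measured. It keeps the core of compound 1 and differs from it in a single place: 3,3,3-trifluoro-2-(trifluoromethyl)propyl in place of cyclopentyl on a carbonyl carbon. For the measured compounds named here, no measured pair in this set shows this particular change, so its effect in this assay cannot be read directly from the data. Still, an upward step is expected, meaning that a larger share of compound 3 would be bound than of compound 1. The step a 2.7-fold lower unbound fraction from compound 1 to compound 3 (0.42 log units; beyond the scatter) is expected to lie beyond the scatter, toward a higher bound percentage. For compound 3 in this assay the estimate is 92%, with a range from 82% to 98%.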

Compound 3, plasma protein binding in the Mus musculus assay: 76.7%
Compound 3: the middle estimate sits 2.9-fold (0.46 log units) (unbound fraction) below what was measured, and the stated range ends above it.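

For the compounds shown here, on this carbonyl carbon, with the core of compound 1 held fixed, the only earlier comparison could not speak to the group, since compound 1 and compound 2 differ in their core; here the group alone changes, and a chain of 10 heavy atoms with no ring replaces a cyclopentyl ring of 5 heavy atoms with no shift in the Mus musculus assay (a 1.1-fold higher unbound fraction from compound 1 to compound 3 (0.04 log units; within the scatter)). The same holds in a physicochemical assay for solubility, at pH 6.8 (a lower number here means a less soluble compound, a higher number a more soluble compound), where compound 1 gives 190000 nM and compound 3 gives 200000 nM, which is a 1.1-fold higher number from compound 1 to compound 3 (0.02 log units; within the scatter). This position therefore accepts a change of this size and atom content with both read-outs staying within the scatter, though nothing available explains why the two groups read alike.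

On these data alone, whether the same exchange would also leave plasma binding in place on the core of compound 2 remains open. The compounds shown also do not tell how an amine, a carboxylic acid or a longer chain on this carbonyl carbon would behave in the Mus musculus assay.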